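Moving one methoxy group on the aryl ring

A few compounds are considered here, and "the series" means these few. Any claim that something is new, unique, unknown or untested is made for them only; others in the source may bear on it.

- compound 1 `COc1cc(-c2nccn2C(C)C)cc(OC)c1OC`: > 100000 nM (a limit)
- compound 2 `COc1cc(-c2nccn2CC(C)C)cc(OC)c1OC`: > 100000 nM (a limit)
- compound 3 `COc1cccc(-n2ccnc2-c2cc(OC)c(OC)c(OC)c2)c1`: 18900 nM

These results come from a functional assay on HT-29 cells (Homo sapiens) for antiproliferative activity, read by MTT assay, with a stated time of 72 h; a lower number here means a stronger inhibitor, a higher number a weaker inhibitor. Compound 1 reaches only a limit, > 100000 nM. Compound 2 also reaches only a limit, > 100000 nM. Compound 3, at 18900 nM, is the only one of the three with an actual number.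

Compound 4 `COc1ccc(-n2ccnc2-c2cc(OC)c(OC)c(OC)c2)cc1` carries 4-methoxyphenyl in place of 3-methoxyphenyl on an aromatic nitrogen. Among the compounds with values here, no measured step makes this exact swap. The nearest evidence is the arrival of 3-methoxyphenyl itself on that nitrogen, replacing isopropyl in an at least 5.2-fold lower number from compound 1 to compound 3 (0.72 log units; beyond the scatter) and isobutyl in an at least 5.2-fold lower number from compound 2 to compound 3 (0.72 log units; beyond the scatter). Those steps show that the group at this place can change the result, but not what moving its methoxy group will do. A modest fall is therefore expected, with much uncertainty, and the expected step is a 3.8-fold lower number from compound 3 to compound 4 (0.58 log units; beyond the scatter). The estimated value for compound 4 is 5000 nM, within an expected range of 400 nM to 50000 nM.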

Compound 4, half-maximal inhibitory concentration: 13100 nM
Beside the measured number, compound 4's estimate is 2.6-fold (0.42 log units) below it; the range from low to high includes it.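

In this assay, moving the methoxy group from 3-methoxyphenyl to 4-methoxyphenyl on the aromatic nitrogen makes no clear difference, with a 1.4-fold lower number from compound 3 to compound 4 (0.16 log units; within the scatter). The earlier advantage of an aryl group over the two alkyl groups therefore does not depend on this choice of methoxy placement, as isobutyl to 4-methoxyphenyl gives an at least 7.6-fold lower number from compound 2 to compound 4 (0.88 log units; beyond the scatter) and isopropyl to 4-methoxyphenyl gives an at least 7.6-fold lower number from compound 1 to compound 4 (0.88 log units; beyond the scatter). The true size of these two steps remains unknown, as they start from a limit rather than a number: the limit of > 100000 nM in this assay, at which 2 of the 4 values shown sit.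

Going by these compounds, what a plain phenyl group, or an amine or a carboxylic acid in place of the methoxy group, would do at this position stays open. So does the part played by the three methoxy groups on the shared core.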